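From hydroxy to methyl on the shared core

A few compounds are considered here, and "the series" means these few. Any claim that something is new, unique, unknown or untested is made for them only; others in the source may bear on it.

Measured in a functional assay on HCT-116 cells (Homo sapiens) for antiproliferative activity, read by CellTiter-Glo, with a stated time of 10 days; a lower number here means a stronger inhibitor, a higher number a weaker inhibitor:
compound 1 `Cn1ncc(-c2cc(Cl)c3c(=O)[nH]nc(CN)c3c2)c1-c1sc2ccccc2c1C#N` gives 52 nM
compound 2 `CCOc1cc(-c2cnn(C)c2-c2sc3ccccc3c2C#N)cc2c(CN)n[nH]c(=O)c12` gives 150 nM
compound 3 `Cn1ncc(-c2cc(O)c3c(=O)[nH]nc(CN)c3c2)c1-c1sc2ccccc2c1C#N` gives 188 nM

Compound 3 (188 nM) sits at the upper end of the set, level with the ethoxy compound (a 1.3-fold higher number from compound 2 to compound 3 (0.10 log units; within the scatter)) and apart from the chloro compound (a 3.6-fold higher number from compound 1 to compound 3 (0.56 log units; beyond the scatter)). Compound 4 (`Cc1cc(-c2cnn(C)c2-c2sc3ccccc3c2C#N)cc2c(CN)n[nH]c(=O)c12`) has methyl in place of hydroxy on an aromatic carbon. Among the measured compounds shown here, no measured compound carries methyl there, so the evidence is indirect. Replacing chloro gave modest steps, with ethoxy (a 2.9-fold higher number from compound 1 to compound 2 (0.46 log units; beyond the scatter)) as with hydroxy (a 3.6-fold higher number from compound 1 to compound 3 (0.56 log units; beyond the scatter)). Both compounds with oxygen at this place lie above compound 1 (52 nM). Without oxygen there, a modest move back towards that value is expected in this assay. The estimated step is (a 2.1-fold lower number from compound 3 to compound 4 (0.32 log units; beyond the scatter)) in size. Compound 4 is expected near 90 nM (estimated range 35 nM to 220 nM).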

Compound 4, half-maximal inhibitory concentration: 30 nM
The estimate for compound 4 lay 3.0-fold (0.48 log units) above the measured number, and the stated range ends above it.
By their numbers in this assay, from the lowest: compounds 4 and 1 (each within the scatter of the next); then compounds 2 and 3 (each within the scatter of the next).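

In this assay methyl on this aromatic carbon gives a clearly lower number than hydroxy (a 6.3-fold lower number from compound 3 to compound 4 (0.80 log units; beyond the scatter)) and ethoxy (a 5.0-fold lower number from compound 2 to compound 4 (0.70 log units; beyond the scatter)), while it stands level with chloro (a 1.7-fold lower number from compound 1 to compound 4 (0.24 log units; within the scatter)). The four compounds thus fall into two groups, with the two carrying oxygen at this place lying together and the two without it, methyl and chloro, lying together. Nothing given here explains this split.

As far as these compounds go, whether an amine, fluoro or a longer chain such as propyl on this carbon would join the methyl and chloro compounds stays open. So does whether the split holds beyond the shared core.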